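The compounds below may be only part of what the source reports. "The series", "measured", "known", "first", "only" and "open" are said of these compounds alone.

In a functional assay on ileum (Cavia porcellus) for antagonist activity, with a stated time of 30 s (a lower number here means a stronger inhibitor, a higher number a weaker inhibitor), compound 1 `O=C(O)c1cc(=O)c2ccc(OCCOc3ccccc3)cc2o1` gives 15 ug/mL and compound 2 `O=C(O)c1cc(=O)c2ccc(OCCCOc3ccccc3)cc2o1` gives 1.4 ug/mL, the lower of the two numbers. Compound 3 `O=C(O)c1cc(=O)c2ccc(OCCCCCc3ccccc3)cc2o1` has phenethyl in place of phenoxy on a saturated chain carbon, three bonds along the chain from an oxygen on an aromatic ring. Within the data shown here, one measured step bears on this, an 11-fold lower number from compound 1 to compound 2 (1.03 log units; beyond the scatter), which is large and beyond the scatter, with phenoxymethyl in place of phenoxy. It changes the same chain but is not the same exchange, so only a slight lean to a lower number is expected in this assay, with no step beyond the scatter. The expected step is a 1.4-fold lower number from compound 2 to compound 3 (0.15 log units; within the scatter). For compound 3 the estimate is 1 ug/mL, with an expected range of 0.3 ug/mL to 4 ug/mL.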

Compound 3, half-maximal inhibitory concentration: 0.6 ug/mL
The estimate for compound 3 lay 1.7-fold (0.22 log units) above the measured number; the measured number falls inside the stated range.
By their numbers in this assay, from the lowest: compound 3; then compound 2; then compound 1.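

In this assay, phenethyl in place of phenoxy gives a 2.3-fold lower number from compound 2 to compound 3 (0.37 log units; beyond the scatter), so the number keeps falling when the phenoxy oxygen, and with it the hydrogen-bond acceptor of that group, leaves the chain. The earlier step, an 11-fold lower number from compound 1 to compound 2 (1.03 log units; beyond the scatter), kept that oxygen and showed nothing about an all-carbon link to the phenyl ring. Nothing measured here accounts for the drop.

The exchange removes the oxygen and adds a carbon at once, and the compounds shown do not separate the two. On these data alone, how a longer chain or an amine at this place would read remains open.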